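A Pyrazinyl Ring Replaces a Cyanoalkyl Chain

The source may hold more compounds than are shown below. What is called first, only, known or untested is meant among the compounds shown, and "the series" means these compounds.

Of the compounds shown here, two have been measured for solubility. Compound 1 `N#Cc1c(N)nc2nc(Cc3ccccc3)ncc2c1N` gives 13000 nM in a physicochemical assay for solubility, in phosphate buffer, with a stated time of 18 h; on this read-out higher numbers stand for higher solubility and lower numbers for lower solubility. Compound 2 `CC(C)(C)c1nc(CCCCC#N)c2c(N)c(C#N)c(N)nc2n1` gives 16000 nM in this assay, the higher of the two numbers, though the gap to compound 1 lies within the scatter of repeated measurements, so the two compounds cannot be ranked against each other on this read-out. Among the compounds with values here, no step between measured compounds that differ in one place has been recorded. Compound 3 `CC(C)(C)c1nc(-c2cnccn2)c2c(N)c(C#N)c(N)nc2n1` is not yet measured. It differs from compound 2 in one place: pyrazin-2-yl in place of 4-cyanobutyl on an aromatic carbon. Within the data shown here, with no comparable step among the measured compounds, the size of this change can only be guessed. For compound 3 the expected step is a 1.3-fold lower number from compound 2 to compound 3 (0.12 log units; within the scatter), no larger than the scatter in either direction. Compound 3 is therefore estimated at 12000 nM, within a range from 4000 nM to 35000 nM.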

Compound 3, solubility: 86000 nM
The estimate for compound 3 lay 7.2-fold (0.86 log units) below the measured number; measured number above the stated range.
By their numbers in this assay, from the lowest: compounds 1 and 2 (each within the scatter of the next); then compound 3.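

Putting pyrazin-2-yl in place of 4-cyanobutyl on this aromatic carbon gives a 5.4-fold higher number from compound 2 to compound 3 (0.73 log units; beyond the scatter) in this assay and so takes the series beyond the scatter, which the two earlier compounds did not do. The position is therefore not indifferent to what it carries, even though the group that leaves and the group that enters each have the same number of heavy atoms, and the change swaps an open chain with a nitrile for a six-membered aromatic ring with two hetero atoms. No measurement shown bears on the reason for this step.

The compounds shown leave open whether the step follows the arrival of the pyrazine ring or the departure of the nitrile. A phenyl ring or a plain pentyl chain on the same carbon would separate the two.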